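The source may report more compounds than this note shows. Statements on the series, on what has been measured and on what is new or still open speak of the compounds shown alone.

Measured in a functional assay on MDA-MB-231 cells (Homo sapiens) for antiproliferative activity, read by MTT assay, with a stated time of 96 h; a lower number here means a stronger inhibitor, a higher number a weaker inhibitor:
- Compound 1 `CC(C)=CCC/C(C)=C/CC/C(C)=C/CC[C@]1(C)CCc2c(C)c(OC(=O)NS(=O)(=O)c3ccc(Cl)cc3)c(C)c(C)c2O1`: > 10000 nM, a limit
- Compound 2 `CC(C)=CCC/C(C)=C/CC/C(C)=C/CC[C@]1(C)CCc2c(C)c(OC(=O)NS(=O)(=O)c3ccc(C)cc3)c(C)c(C)c2O1`: > 10000 nM, a limit

Compound 1 stands at the limit of > 10000 nM in this assay, at which 2 of the 2 values shown sit, so no number places it. Compound 3 `CC(C)=CCC/C(C)=C/CC/C(C)=C/CC[C@]1(C)CCc2cc(OC(=O)NS(=O)(=O)c3ccc(Cl)cc3)c(C)c(C)c2O1` differs from compound 1 by a single change, (hydrogen in place of methyl on an aromatic carbon), with hydrogen in place of methyl on an aromatic carbon, ortho to a large group. For the measured compounds named here, the only measured step, a step that the two limits leave unreadable from compound 1 to compound 2, concerns another change, methyl in place of chloro on an aromatic carbon, and it has no readable size. Going by the values given here, no measured step therefore bears directly on this change, and none offers a size to carry over. Compound 3 is expected to remain weak in this assay, perhaps with a modest shift towards stronger inhibition. The expected step is an at least 1.1-fold lower number from compound 1 to compound 3 (0.04 log units; that floor lies within the scatter). For compound 3 the estimate is 9000 nM, with an expected range from 3000 nM to 30000 nM.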

Compound 3, half-maximal inhibitory concentration: > 10000 nM
Compound 3: a limit, no number (the forecaster's own chance of this, stated with the estimate: 50%); at least 1.1-fold (0.04 log units) between middle value and limit.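

In this assay compound 3 gives > 10000 nM, a limit and not a number. Compound 1 also sits at a limit, so no step from compound 1 to compound 3 can be read: the limit of > 10000 nM in this assay, at which 3 of the 3 values shown sit.

The compounds shown leave open how far either single change moves the activity in this assay.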